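A few compounds are considered here, and "the series" means these few. Any claim that something is new, unique, unknown or untested is made for them only; others in the source may bear on it.

Measured in an ADME assay on Vero cells (Chlorocebus sabaeus) for cytotoxicity, read by trypan blue exclusion, with a stated time of 24 h; a lower number here means a stronger inhibitor, a higher number a weaker inhibitor:
compound 1 (`COc1cc(C[C@@H](C)[C@@H](C)Cc2ccc(OC(=O)c3cccnc3)c(OC)c2)ccc1O`) 71.4 ug/mL
compound 2 (`COc1cc(C[C@@H](C)[C@@H](C)Cc2ccc(OC(=O)c3cnccn3)c(OC)c2)ccc1O`) 43.3 ug/mL

Among the measured compounds shown here, compound 1 stands within the scatter of compound 2, the only other measured compound. Compound 3 (`COc1cc(C[C@@H](C)[C@@H](C)Cc2ccc(OC(=O)c3cccnc3)c(OC)c2)ccc1OC(=O)c1cccnc1`) has (pyridin-3-yl)carbonyl in place of hydrogen on an oxygen on an aromatic ring. For the measured compounds named here, the one measured step (a 1.6-fold lower number from compound 1 to compound 2 (0.22 log units; within the scatter)) is pyrazin-2-yl in place of pyridin-3-yl on a carbonyl carbon, so it bears only loosely on this change, and no measured step tests the change itself. In this assay, no step beyond the scatter is expected (a 1.1-fold lower number from compound 1 to compound 3 (0.04 log units; within the scatter)). Compound 3 is estimated at 65 ug/mL (expected range 25 ug/mL to 160 ug/mL).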

Compound 3, half-maximal inhibitory concentration: 36.3 ug/mL
Compound 3: the middle estimate sits 1.8-fold (0.25 log units) above what was measured, and the stated range covers the measured number.
By their numbers in this assay, from the lowest: compounds 3, 2 and 1 (each within the scatter of the next).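

In this assay the change from hydroxy to ((pyridin-3-yl)carbonyl)oxy gives a 2.0-fold lower number from compound 1 to compound 3 (0.29 log units; within the scatter) so this oxygen on an aromatic ring carries a second (pyridin-3-yl)carbonyl with no step beyond the scatter. Among the compounds shown here, the earlier step changed only the ring on the existing carbonyl carbon, whereas this is the first reading at the free hydroxy itself. Nothing available explains this result.

From the compounds shown here alone, whether a smaller acetyl group on this oxygen would also stay within the scatter remains open. So does the effect of an acyl group carrying an amine or a carboxylic acid there.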